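This account rests on a few compounds, and the source may have more. Where it says the series, first, only, none or still open, it means among the compounds named here.

In a functional assay on MDA-MB-468 cells (Homo sapiens) for antiproliferative activity, read by MTT assay, with a stated time of 72 h (on this read-out higher numbers stand for weaker inhibition and lower numbers for stronger inhibition), compound 1 `O=C(Nc1ccc(Cl)c(-c2nnc3c(Cl)cccn23)c1)c1ccc(C(F)(F)F)cc1Cl` gives only a limit, > 100000 nM. Compound 2 `O=C(Nc1ccc(Cl)c(-c2nnc3c(Cl)cccn23)c1)c1ccc(F)cc1Cl` likewise gives only a limit, > 100000 nM. For the measured compounds named here, compound 3 `O=C(Nc1ccc(Cl)c(-c2nnc3c(Cl)cccn23)c1)c1cccc(Cl)c1` gives 54800 nM, the only number among the three values shown. The step that the two limits leave unreadable from compound 1 to compound 2 cannot be sized. The step of an at least 1.8-fold lower number from compound 2 to compound 3 (0.26 log units; that floor lies within the scatter) is a floor only, because its start is the limit of > 100000 nM in this assay, at which 2 of the 3 values shown sit. Compound 4 `CS(=O)(=O)c1cccc(C(=O)Nc2ccc(Cl)c(-c3nnc4c(Cl)cccn34)c2)c1` differs from compound 3 by methylsulfonyl in place of chloro on an aromatic carbon. Going by the values given here, no measured step covers this change, and the readable steps show only weak inhibition throughout, so no shift beyond the scatter is expected, with a fair chance that a limit alone is returned. Compound 4 is estimated at 70000 nM, between 20000 nM and 200000 nM, an expected step of a 1.3-fold higher number from compound 3 to compound 4 (0.11 log units; within the scatter).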

Compound 4, half-maximal inhibitory concentration: > 100000 nM
Compound 4: no number, only a limit (the forecaster's own chance of this, stated with the estimate: 45%); middle value at least 1.4-fold (0.15 log units) from the limit.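

In this assay, methylsulfonyl in place of chloro on this aromatic carbon, meta to a large group, gives an at least 1.8-fold higher number from compound 3 to compound 4 (0.26 log units; that floor lies within the scatter) and no gain in inhibition. For the compounds shown here, compound 4 gives only a limit, so compound 3 remains the only compound here with a number. As far as these compounds go, the true size of this step stays unknown, and the step from compound 2 to compound 4 cannot be read, because each rests on a limit: the limit of > 100000 nM in this assay, at which 3 of the 4 values shown sit.

From the compounds shown here alone, what an amine or a carboxylic acid would give at this position remains open, as does whether any group here can move the number beyond the scatter.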